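The source may hold more compounds than are shown below. What is called first, only, known or untested is meant among the compounds shown, and "the series" means these compounds.

Measured compounds:
- Compound 1, `C=C1C[C@]23C[C@@]1(O)CC[C@H]2c1ccc(OS(=O)(=O)c2ccc(C)cc2)c(C)c1[C@@H]3Cn1cc(-c2ccc(OC)cc2)nn1`, in a functional assay on A549 cells (Homo sapiens) for cytotoxicity, read by MTT assay, with a stated time of 4 days (on this read-out lower numbers stand for stronger inhibition and higher numbers for weaker inhibition), gives only the assay limit > 20000 nM.
- Compound 2, `C=C1C[C@]23C[C@@]1(O)CC[C@H]2c1ccc(OS(=O)(=O)c2ccc(C)cc2)c(C)c1[C@@H]3Cn1cc(-c2ccc(F)cc2)nn1`, in this assay likewise reaches only the limit > 20000 nM.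
- Compound 3, `C=C1C[C@]23C[C@@]1(O)CC[C@H]2c1ccc(OS(=O)(=O)c2ccc(C)cc2)c(C)c1[C@@H]3Cn1cc(-c2ccccc2)nn1`, in this assay also stops at the limit > 20000 nM.

Compound 3 therefore stands at the limit, as do the two others; none of the three gives a number. The steps among them, a step that the two limits leave unreadable from compound 1 to compound 2, a step that the two limits leave unreadable from compound 1 to compound 3 and a step that the two limits leave unreadable from compound 2 to compound 3, cannot be sized, because of the limit of > 20000 nM in this assay, at which 3 of the 3 values shown sit.

Compound 4, `C=C1C[C@]23C[C@@]1(O)CC[C@H]2c1ccc(OS(=O)(=O)c2ccc(C)cc2)c(C)c1[C@@H]3Cn1cc(-c2ccccn2)nn1`, differs from compound 3 by pyridin-2-yl in place of phenyl on an aromatic carbon. Among the measured compounds shown here, no measured step bears on this change in a readable way, since every value so far is a limit. The expected step of a number no higher from compound 3 to compound 4 (the limit leaves the size open) is therefore set at none beyond the scatter, with the most likely outcome again a limit. Compound 4 is estimated at 20000 nM in this assay, with a range from 8000 nM to 20000 nM.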

Compound 4, half-maximal inhibitory concentration: > 20000 nM
Compound 4: a limit, no number; the forecaster's own chance of this, stated with the estimate: 85%; the middle value sits exactly at the limit.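

Among the compounds shown here, no step to compound 4 can be read from compound 1, compound 2 or compound 3, since each of the four gives a limit and not a number: the limit of > 20000 nM in this assay, at which 4 of the 4 values shown sit. The compounds shown leave open whether pyridin-2-yl in place of phenyl changes anything in this assay.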